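Chloro for methyl on the five-membered ring of compound 1

A few compounds are considered here, and "the series" means these few. Any claim that something is new, unique, unknown or untested is made for them only; others in the source may bear on it.

For the measured compounds named here, compound 1 `Cc1nn(C)c2c1C(c1ccccc1)=NCC(=O)N2` gives 10 mg/kg in a functional assay on the whole organism (strain Holtzman) with Rattus norvegicus as the target (on this read-out higher numbers stand for an effect only at larger amounts of compound and lower numbers for an effect already at smaller amounts), the lowest of the two numbers measured so far. Compound 2 `Cc1nn(C)c2c1C(c1cccs1)=NCC(=O)N2` gives 40 mg/kg in this assay, and the step of a 4.0-fold higher number from compound 1 to compound 2 (0.60 log units; beyond the scatter) marks a change at the carbon with a double bond to nitrogen, not at the five-membered ring.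

Compound 3 `Cn1nc(Cl)c2c1NC(=O)CN=C2c1ccccc1` differs from compound 1 by chloro in place of methyl on an aromatic carbon. Going by the values given here, no measured step touches this position: the only step known, from phenyl to thiophen-2-yl, concerns a different part of the shared core and cannot be carried over. With nothing to anchor a direction, the expectation is a step no larger than the usual scatter, stated as no change at the digits printed from compound 1 to compound 3 (within the scatter), in either direction.

Compound 3 is therefore estimated at 10 mg/kg in this assay, with a range from 3 mg/kg to 40 mg/kg that reflects the absence of any comparable step.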

Compound 3, minimum effective dose: 40 mg/kg
For compound 3 the middle estimate is 4.0-fold (0.60 log units) below the measured one; low and high end bracket the measured number.
By their numbers in this assay, from the lowest: compound 1; then compounds 2 and 3 (each within the scatter of the next).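

This position on the five-membered aromatic ring responds to substitution: in this assay, chloro in place of methyl gives a 4.0-fold higher number from compound 1 to compound 3 (0.60 log units; beyond the scatter), a step beyond the scatter. The earlier compounds shown here showed a change only at the carbon with a double bond to nitrogen, and the step there, a 4.0-fold higher number from compound 1 to compound 2 (0.60 log units; beyond the scatter), has the same printed size, so within this small set the methyl position is a site where a single replacement moves the number as far as the change of phenyl did. No evidence at hand bears on why the number moves in this direction.

As far as these compounds go, whether any replacement at this carbon gives a lower number than compound 1 stays open: hydrogen, ethyl, methoxy or an amine there would test this. Also open, from the compounds shown here alone, is whether the chloro step holds with thiophen-2-yl in place of phenyl on the shared core.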